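Aryl variation on the hydrazone of a shared core

The source may report more compounds than this note shows. Statements on the series, on what has been measured and on what is new or still open speak of the compounds shown alone.

Measured so far in a functional assay on MKN-45 cells (Homo sapiens) for cytotoxicity, read by MTT assay, with a stated time of 72 h; a higher number here means a weaker inhibitor, a lower number a stronger inhibitor:
compound 1 `COc1ccc(/C=N/NC(=O)Nc2ccc(Oc3ccnc(-c4nncn4CCN(C)C)c3)c(F)c2)c(OC)c1`: 1680 nM
compound 2 `CN(C)CCn1cnnc1-c1cc(Oc2ccc(NC(=O)N/N=C/c3ccc(O)c(Br)c3)cc2F)ccn1`: 1860 nM
compound 3 `COc1cc(/C=N/NC(=O)Nc2ccc(Oc3ccnc(-c4nncn4CCN(C)C)c3)c(F)c2)cc(OC)c1OC`: 2900 nM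

Compound 3 stands at the high end of the three numbers in this assay, but each step to it lies within the scatter: a 1.7-fold higher number from compound 1 to compound 3 (0.24 log units; within the scatter) and a 1.6-fold higher number from compound 2 to compound 3 (0.19 log units; within the scatter); likewise a 1.1-fold higher number from compound 1 to compound 2 (0.04 log units; within the scatter). The aryl group on the carbon with a double bond to nitrogen has so far been exchanged without any effect beyond the scatter.

Compound 4 `CN(C)CCn1cnnc1-c1cc(Oc2ccc(NC(=O)N/N=C/c3ccc(Cl)cc3)cc2F)ccn1` is not yet measured; it carries 4-chlorophenyl in place of 3,4,5-trimethoxyphenyl on a carbon with a double bond to nitrogen. All three measured steps bear on it, as each exchanged the same aryl group, and each stayed within the scatter. For compound 4 a step of a 1.4-fold lower number from compound 3 to compound 4 (0.14 log units; within the scatter) is therefore expected, with no direction beyond the scatter. Compound 4 is estimated at 2100 nM, range 800 nM to 5500 nM.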

Compound 4, half-maximal inhibitory concentration: 570 nM
Beside the measured number, compound 4's estimate is 3.7-fold (0.57 log units) above it; measured number below the stated range.
By their numbers in this assay, from the lowest: compound 4; then compounds 1, 2 and 3 (each within the scatter of the next).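

In this assay, among these compounds, this position no longer looks indifferent to the aryl group on the carbon with a double bond to nitrogen: 4-chlorophenyl gives the first exchanges beyond the scatter (a 5.1-fold lower number from compound 3 to compound 4 (0.71 log units; beyond the scatter)), (a 3.3-fold lower number from compound 2 to compound 4 (0.51 log units; beyond the scatter)) and (a 2.9-fold lower number from compound 1 to compound 4 (0.47 log units; beyond the scatter)). Of the four aryl groups shown, only 4-chlorophenyl carries no oxygen. Nothing available explains these steps.

Chlorine and the absence of oxygen arrive together, so the compounds shown cannot separate them. Plain phenyl and 4-methylphenyl at this position remain open comparisons.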